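Compound 1 to compound 4: bromo in place of propoxy

The source may hold more compounds than are shown below. What is called first, only, known or untested is meant among the compounds shown, and "the series" means these compounds.

Within the data shown here, in a functional assay on MT4 cells (Homo sapiens) for cytotoxicity (a lower number here means a stronger inhibitor, a higher number a weaker inhibitor), compound 1 `CCCOc1cc(C)cc(S(=O)(=O)c2cccc(N)c2C#N)c1` gives 11000 nM, the only actual number available for the series. Compound 2 `N#Cc1c(N)cccc1S(=O)(=O)c1ccc(Cl)cc1` gives > 5000 nM, which is a limit. Compound 3 `N#Cc1ccc(S(=O)(=O)c2cccc(N)c2C#N)cc1` gives > 200000 nM, which is also a limit. The position of compound 1 relative to these two therefore remains only loosely defined.

The next compound, compound 4 `Cc1cc(Br)cc(S(=O)(=O)c2cccc(N)c2C#N)c1`, keeps the core of compound 1 and carries bromo in place of propoxy on an aromatic carbon. Among the measured compounds shown here, the one measured step, a step that the two limits leave unreadable from compound 2 to compound 3, has no readable size and concerns cyano in place of chloro, so it offers no guide to the size or direction of this change. For the measured compounds named here, with no step to support a shift, the expected change in this assay does not go beyond the scatter, though the uncertainty is wide. The estimated step is a 1.4-fold higher number from compound 1 to compound 4 (0.13 log units; within the scatter). For compound 4 the expected value is 15000 nM, with an estimated range from 4000 nM to 70000 nM.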

Compound 4, half-maximal inhibitory concentration: 133000 nM
Beside the measured number, compound 4's estimate is 8.9-fold (0.95 log units) below it; measured number outside the range, above it.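

In this assay, among these compounds, putting bromo in place of propoxy gives a 12-fold higher number from compound 1 to compound 4 (1.08 log units; beyond the scatter) and is the one change with a readable size. Among the compounds shown here, this position on the aromatic carbon, meta to a large group and meta to a methyl group, therefore responds to substitution, which the earlier compounds could not show: their only step lies between two limits and cannot be read. Of this pair, the lower number goes with propoxy, so bromo does not preserve the value of compound 1 at this position.

Going by these compounds, whether a methoxy group, a longer alkoxy chain or an amine at the same position would give a number nearer to that of compound 1 or compound 4 remains open. Nothing shown gives a cause for the step.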